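The compounds below may be only part of what the source reports. "The series", "measured", "known", "first", "only" and "open" are said of these compounds alone.

Measured so far in a functional assay on HT-29 cells (Homo sapiens) for cytotoxicity, read by MTT assay, with a stated time of 48 h (a higher number here means a weaker inhibitor, a lower number a stronger inhibitor), as follows:
- compound 1 `CCCCOC(=O)/C=C/c1ccc2c(c1)C(=O)C(=O)N2Cc1ccc(OC)cc1` gives 420 nM
- compound 2 `COC(=O)/C=C/c1ccc2c(c1)C(=O)C(=O)N2Cc1ccc2ccccc2c1` gives 100 nM
- compound 3 `COC(=O)/C=C/c1ccc2c(c1)C(O)C(=O)N2Cc1ccc(OC)cc1` gives 320 nM

Compound 1 at 420 nM lies within the scatter of compound 3 at 320 nM and so sits level with it. Compound 2 at 100 nM gives a lower number than compound 1, and that gap lies beyond the scatter. Among the measured compounds shown here, these three compounds differ in more than one place, so no measured pair isolates a single change.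

The next compound is compound 4 `COc1ccc(CN2C(=O)C(=O)c3cc(/C=C/C(=O)N4CCCC4)ccc32)cc1`, which has pyrrolidin-1-yl in place of butoxy on a carbonyl carbon turns butoxycarbonyl into (pyrrolidin-1-yl)carbonyl, and the rest of compound 1 stays as it is. For the measured compounds named here, no measured compound carries pyrrolidin-1-yl on that carbonyl carbon, so the series offers no direct precedent, and compound 1 at 420 nM is the only anchor. A moderate loss of strength is the cautious expectation, though a step within the scatter cannot be excluded. The estimated change is a 1.9-fold higher number from compound 1 to compound 4 (0.28 log units; within the scatter) in this assay as a move toward a higher number. Compound 4 is estimated at 800 nM with an expected range from 200 nM to 4000 nM for now.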

Compound 4, half-maximal inhibitory concentration: 5230 nM
For compound 4 the middle estimate is 6.5-fold (0.82 log units) below the measured one; measured number outside the range, above it.
By their numbers in this assay, from the lowest: compound 2; then compounds 3 and 1 (each within the scatter of the next); then compound 4.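

In this assay, among the compounds shown here, the exchange of butoxy for pyrrolidin-1-yl on a carbonyl carbon gives the first single-place step (a 12-fold higher number from compound 1 to compound 4 (1.10 log units; beyond the scatter)), and that step is large, so the group on this carbonyl carbon strongly affects the number in this assay. The heavy-atom count stays the same across the change, while oxygen gives way to nitrogen, the open chain gives way to a five-membered non-aromatic ring, and the hydrogen-bond acceptor counted on butoxy is gone, so a step of this size does not need a change in that count. Nothing available here bears on why the step is so large.

The nitrogen link and the ring enter together, so a diethylamino group on the same carbonyl carbon would be needed to separate them, and a piperidin-1-yl group or a carboxylic acid there would further define how far this position tolerates change. As far as these compounds go, compounds 2 and 3 carry methoxy on that carbonyl carbon but also differ from compound 1 elsewhere, so the effect of the ester chain length remains open.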